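The source may hold more compounds than are shown below. What is called first, only, known or untested is meant among the compounds shown, and "the series" means these compounds.

Measured compounds:
- Compound 1 `O=C(O)C[C@@H](NC(=O)[C@@H]1CCN1S(=O)(=O)c1cc(Cl)cc(Cl)c1)c1ccc(F)cc1` gives 3.2 nM in an assay on RPMI-8866 cells for inhibition of integrin alpha-4/beta-1 (Homo sapiens); on this read-out lower numbers stand for stronger inhibition and higher numbers for weaker inhibition
- Compound 2 `O=C(O)C[C@@H](NC(=O)[C@@H]1CCN1S(=O)(=O)c1cc(Cl)cc(Cl)c1)c1ccc(OC2CC2)cc1` gives 0.31 nM in this assay
- Compound 3 `O=C(O)C[C@@H](NC(=O)[C@@H]1CCN1S(=O)(=O)c1cc(Cl)cc(Cl)c1)c1ccc(Oc2ccccc2)cc1` gives 3.1 nM in this assay

Compound 3 stands second highest of the three numbers in this assay. Its value and that of compound 1 lie within the usual scatter of each other, so nothing separates them; compound 2 sits clearly apart, as the step of a 10-fold higher number from compound 2 to compound 3 (1.00 log units; beyond the scatter) shows.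

Compound 4 `O=C(O)C[C@@H](NC(=O)[C@@H]1CCN1S(=O)(=O)c1cc(Cl)cc(Cl)c1)c1ccc(OCF)cc1` has not yet been measured. It differs from compound 3 by fluoromethyl in place of phenyl on an oxygen on an aromatic ring.

Going by the values given here, two measured steps bear on this change. The step of a 1.0-fold lower number from compound 1 to compound 3 (0.01 log units; within the scatter) shows that adding phenoxy in place of fluoro changed nothing beyond the scatter, while a 10-fold lower number from compound 1 to compound 2 (1.01 log units; beyond the scatter) shows that a smaller group on that oxygen gave a markedly lower number. Fluoromethyl, like cyclopropyl, is far smaller than phenyl, so compound 4 is expected to move toward compound 2, though with fewer examples of small groups the size of the step is uncertain; the step of a 3.1-fold lower number from compound 3 to compound 4 (0.49 log units; beyond the scatter) is the expectation here. Compound 4 is therefore estimated at 1 nM in this assay, within a range from 0.3 nM to 3.2 nM.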

Compound 4, half-maximal inhibitory concentration: 0.72 nM
Compound 4: middle estimate off by 1.4-fold (0.14 log units), on the high side; the measured number falls inside the stated range.
By their numbers in this assay, from the lowest: compound 2; then compound 4; then compounds 3 and 1 (each within the scatter of the next).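

The oxygen on the aromatic ring now carries a second group much smaller than phenyl, and a 4.3-fold lower number from compound 3 to compound 4 (0.63 log units; beyond the scatter) comes with that swap, so the low number of compound 2 is no longer a lone case among these compounds. Measured against fluoro on the aromatic carbon, fluoromethoxy gives a 4.4-fold lower number from compound 1 to compound 4 (0.65 log units; beyond the scatter) and so runs the same way as cyclopropyloxy, whereas phenoxy stayed within the scatter. The two small groups still differ, with a 2.3-fold higher number from compound 2 to compound 4 (0.37 log units; beyond the scatter) separating cyclopropyl from fluoromethyl, so being smaller than phenyl does not by itself settle the number.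

Nothing measured here gives a reason for these differences. As far as these compounds go, whether a plain methyl, a trifluoromethyl or a longer chain on the same oxygen would sit nearer compound 2 or compound 4 stays open.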